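The source may hold more compounds than are shown below. What is called first, only, known or untested is meant among the compounds shown, and "the series" means these compounds.

Compound 1 `O=c1c(-c2cccc([N+](=O)[O-])c2)nc2ccccc2n1Cc1ccccc1` and compound 2 `O=c1c(-c2cccc([N+](=O)[O-])c2)nc2cc(Cl)ccc2n1Cc1ccccc1` share one core. In an assay on cells for activation of Cystic fibrosis transmembrane conductance regulator (Homo sapiens), read by fluorescence, with a stated time of 10 min (on this read-out higher numbers stand for an effect only at larger amounts of compound and lower numbers for an effect already at smaller amounts), compound 1 gives 9 nM, and compound 2 gives 70 nM, the higher of the two numbers, after the step of a 7.8-fold higher number from compound 1 to compound 2 (0.89 log units; beyond the scatter). Compound 3 `O=c1c(-c2cccc([N+](=O)[O-])c2)nc2cc(Br)ccc2n1Cc1ccccc1` carries bromo in place of chloro on an aromatic carbon. For the measured compounds named here, no measured step swaps one halogen for another, so only the modest chloro-for-hydrogen step bears on it, and it does not fix a direction. For compound 3 the step of no change at the digits printed from compound 2 to compound 3 (within the scatter) in this assay is expected to stay within the scatter. Compound 3 is estimated at 70 nM in this assay, with a range from 25 nM to 200 nM.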

Compound 3, half-maximal effective concentration: 63 nM
Estimate against measurement, compound 3: 1.1-fold (0.05 log units) above; the range from low to high includes it.
By their numbers in this assay, from the lowest: compound 1; then compounds 3 and 2 (each within the scatter of the next).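

In this assay, bromo in place of chloro gives a result that cannot separate the two halogens at this position (a 1.1-fold lower number from compound 2 to compound 3 (0.05 log units; within the scatter)). Bromo in place of hydrogen also gives a step beyond the scatter (a 7.0-fold higher number from compound 1 to compound 3 (0.85 log units; beyond the scatter)), so a second halogen here shows a higher number than hydrogen, as chloro did. Nothing measured here gives a reason for this.

As far as these compounds go, whether fluoro, an amine or a carboxylic acid at this position would give a number as low as that of compound 1 stays open. So does whether bromo and chloro match at other places on the shared core.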